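The source may report more compounds than this note shows. Statements on the series, on what has been measured and on what is new or still open speak of the compounds shown alone.

Values in a functional assay on HCT-116 cells (Homo sapiens) for cytotoxicity, read by MTT assay, with a stated time of 48 h (on this read-out lower numbers stand for stronger inhibition and higher numbers for weaker inhibition), follow

- compound 1 `Cc1nc2c3ccccc3ccc2c2nc3c(ccc4ccccc43)c(-c3cccnc3)c12` gives 34200 nM
- compound 2 `Cc1nc2c3ccccc3ccc2c2nc3c(ccc4ccccc43)c(-c3nccnc3N)c12` gives 3560 nM

Of these two, compound 2 has the lower number, which means the stronger inhibition. Compound 3 `Cc1nc2c3ccccc3ccc2c2nc3c(ccc4ccccc43)c(-c3ccccc3N)c12` differs from it in one place: 2-aminophenyl in place of 3-aminopyrazin-2-yl on an aromatic carbon. Going by the values given here, only one measured step bears on this change: a 9.6-fold lower number from compound 1 to compound 2 (0.98 log units; beyond the scatter). That modest step brought in the group that now leaves, but the amino group stays and no measurement tests this swap directly. A small rise in this assay is therefore expected, possibly none beyond the scatter. The expected size is a 1.4-fold higher number from compound 2 to compound 3 (0.15 log units; within the scatter). For compound 3 the estimated value is 5000 nM, within an expected range from 1500 nM to 17000 nM.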

Compound 3, half-maximal inhibitory concentration: 4760 nM
Compound 3: middle estimate off by 1.1-fold (0.02 log units), on the high side, and the stated range covers the measured number.
By their numbers in this assay, from the lowest: compounds 2 and 3 (each within the scatter of the next); then compound 1.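

In this assay, replacing 3-aminopyrazin-2-yl with 2-aminophenyl gives a 1.3-fold higher number from compound 2 to compound 3 (0.13 log units; within the scatter), so at this position a ring of carbon only serves as well as one with 2 hetero atoms. The second amino-bearing ring also stands well clear of pyridin-3-yl, with a 7.2-fold lower number from compound 1 to compound 3 (0.86 log units; beyond the scatter). Nothing measured here explains these results. On these data alone, what a plain phenyl or a 2-hydroxyphenyl group would give remains open. Until then, the part played by the amino group itself cannot be separated from that of the ring carrying it.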